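A Ring Swap at the Edge of Measurement

A few compounds are considered here, and "the series" means these few. Any claim that something is new, unique, unknown or untested is made for them only; others in the source may bear on it.

Three compounds share one core and differ only in the two-ring group attached to the saturated chain carbon bound to a double-bonded chain carbon. Compound 1, `O=C1O/C(=C\Cn2cnc3c(F)nc(F)c(Cl)c32)C(OCc2ccccc2)=C1OCc1ccccc1`, gives 55000 nM in a functional assay on SW-620 cells (Homo sapiens) for antiproliferative activity, read by MTT assay, with a stated time of 72 h; a higher number here means a weaker inhibitor, a lower number a stronger inhibitor. Compound 2, `O=C1O/C(=C\Cn2cnc3cncc(Br)c32)C(OCc2ccccc2)=C1OCc1ccccc1`, gives 32900 nM in this assay, and the step of a 1.7-fold lower number from compound 1 to compound 2 (0.22 log units; within the scatter) is small. Compound 3, `O=C1O/C(=C\Cn2cnc3ccnc(Cl)c32)C(OCc2ccccc2)=C1OCc1ccccc1`, gives > 100000 nM in this assay, which is a limit of the assay and not a number. Compound 3 thus stands at the limit of > 100000 nM in this assay, at which 1 of the 3 values shown sits, the weakest position that can be reported here.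

Among the compounds with values here, two measured steps bear on the change: an at least 1.8-fold higher number from compound 1 to compound 3 (0.25 log units; that floor lies within the scatter) and an at least 3.0-fold higher number from compound 2 to compound 3 (0.48 log units; beyond the scatter). Both lead toward the limit, and only the second is beyond the scatter.

Compound 4, `O=C1O/C(=C\Cn2cnc3ncc(Br)c-3c2)C(OCc2ccccc2)=C1OCc1ccccc1`, is the next step: a group of 10 heavy atoms (6 carbon, 3 nitrogen, 1 bromine; one five-membered aromatic ring with 1 hetero atom, one six-membered aromatic ring with 2 hetero atoms) in place of a group of 10 heavy atoms (6 carbon, 3 nitrogen, 1 chlorine; one five-membered aromatic ring with 2 hetero atoms, one six-membered aromatic ring with 1 hetero atom), on a saturated chain carbon bound to a double-bonded chain carbon. Bromine returns, as in compound 2, but the two rings are rearranged, so the steps known so far are only a loose guide. Because compound 2 with bromine gave 32900 nM, some return toward a measurable number is expected, but the rearranged rings leave that uncertain. Compound 4 is estimated at 60000 nM, with a range from 25000 nM to 150000 nM. The expected step is an at least 1.6-fold lower number from compound 3 to compound 4 (0.22 log units; that floor lies within the scatter), and a second limit rather than a number is a real possibility.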

Compound 4, half-maximal inhibitory concentration: > 100000 nM
Compound 4: only a limit was reported; the forecaster's own chance of this, stated with the estimate: 40%; at least 1.6-fold (0.22 log units) between middle value and limit.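

In this assay, compound 4 joins compound 3 at a limit of the assay, which is not a number: the limit of > 100000 nM in this assay, at which 2 of the 4 values shown sit.

The most informative reading is an at least 3.0-fold higher number from compound 2 to compound 4 (0.48 log units; beyond the scatter). Both compounds carry a bromine-bearing group with the same atom counts, and they differ in the rings: one five-membered aromatic ring with 1 hetero atom and one six-membered aromatic ring with 2 hetero atoms replace one five-membered aromatic ring with 2 hetero atoms and one six-membered aromatic ring with 1 hetero atom, so bromine alone does not secure a measurable number in this set. The other readable step, an at least 1.8-fold higher number from compound 1 to compound 4 (0.25 log units; that floor lies within the scatter), has a floor within the scatter and adds little, while the step between the two limits cannot be read.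

On these data alone, how far compound 3 and compound 4 lie past the limit remains unknown, so chlorine and bromine cannot be ranked on those two compounds. As far as these compounds go, it also remains open whether an amine or a carboxylic acid in place of the bromine of compound 2 would move the number in either direction.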